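The source may report more compounds than this note shows. Statements on the series, on what has been measured and on what is new or still open speak of the compounds shown alone.

Of the compounds shown here, two with a shared core have been measured so far. Compound 1 `CC1CN(C(=O)Nc2cc(F)c(F)c(F)c2)Cc2c(N3CC(C#N)CC3=O)cnn21` was tested in a toxicity assay on HepG2 2.2.15 cells (Homo sapiens) for cytotoxicity, read by CellTiter-Glo (a lower number here means that less compound is tolerated, a higher number that more compound is tolerated), and there compound 1 gives 115000 nM. Compound 2 `O=C1NC(c2ccccc2)CN1c1cnn2c1CN(C(=O)Nc1cc(F)c(F)c(F)c1)C(C1CC1)C2` gives 38500 nM in this assay, the lower of the two numbers, and the gap between the two lies beyond the usual scatter, so compound 2 is tolerated at lower concentrations than compound 1. Compound 3 `O=C1CC(c2ccccn2)CN1c1cnn2c1CN(C(=O)Nc1cc(F)c(F)c(F)c1)C(C1CC1)C2` has not yet been measured. It differs from compound 2 in one place: 2-oxo-4-(pyridin-2-yl)pyrrolidin-1-yl in place of 2-oxo-4-phenylimidazolidin-1-yl on an aromatic carbon. No measured pair in this set shows what such a change does, so the expectation rests on the general observation that exchanges of this kind in a ring of the same size often move a cytotoxicity read-out only modestly. The step from compound 2 to compound 3 is therefore expected to be small, a 1.3-fold higher number from compound 2 to compound 3 (0.11 log units; within the scatter), with no confident direction. For compound 3 the estimated value is 50000 nM, within a range from 20000 nM to 120000 nM.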

Compound 3, half-maximal cytotoxic concentration: 96200 nM
For compound 3 the middle estimate is 1.9-fold (0.28 log units) below the measured one; measured number inside the range.
By their numbers in this assay, from the lowest: compound 2; then compounds 3 and 1 (each within the scatter of the next).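

Placing 2-oxo-4-(pyridin-2-yl)pyrrolidin-1-yl in place of 2-oxo-4-phenylimidazolidin-1-yl on this aromatic carbon gives a 2.5-fold higher number from compound 2 to compound 3 (0.40 log units; beyond the scatter) in this assay, so this exchange of groups with the same atoms is not neutral, and more compound is tolerated after it. Both rings of the group change at once, and the entering group has no hydrogen-bond donor, so this single step cannot assign the shift to either ring. No measurement shown here explains the shift.

The compounds shown leave open which ring carries the step, and 2-oxo-4-phenylpyrrolidin-1-yl, which would change only the five-membered ring, is not among them. Also open, as far as these compounds go, is how this position responds to quite different groups, such as a simple amine or a carboxylic acid.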